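The source may report more compounds than this note shows. Statements on the series, on what has been measured and on what is new or still open speak of the compounds shown alone.

Notes on the series. Compound 1 `CCN(CC)C(=O)Cc1c(-c2ccc(OC3CCCC3)cc2)nn2c(C)cc(C)nc12` carries a cyclopentyl on the oxygen on the aromatic ring; in an assay on isolated protein (kidney, strain Wistar) for displacement of a labelled ligand from Translocator protein (Rattus norvegicus), read by scintillation counting, with a stated time of 90 min (on this read-out lower numbers stand for stronger inhibition and higher numbers for weaker inhibition), compound 1 gives 1.5 nM. Compound 2 `CCN(CC)C(=O)Cc1c(-c2ccc(OCc3ccccc3F)cc2)nn2c(C)cc(C)nc12` differs from it in that place only, and in this assay compound 2 gives 0.31 nM. Going by the values given here, the single recorded step, a 4.8-fold lower number from compound 1 to compound 2 (0.68 log units; beyond the scatter), goes with 2-fluorobenzyl in place of cyclopentyl. Compound 2 therefore stands with the lowest of the two numbers, compound 1 standing apart from it by that step.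

Compound 3 `CCN(CC)C(=O)Cc1c(-c2ccc(OCc3ccc(C(F)(F)F)cc3)cc2)nn2c(C)cc(C)nc12` keeps the shared core and the oxygen on the aromatic ring and differs from compound 2 in one place: 4-(trifluoromethyl)phenyl in place of 2-fluorophenyl on a saturated chain carbon bound to an oxygen on an aromatic ring. Among the compounds with values here, no measured step bears on this exchange directly; the one recorded step, a 4.8-fold lower number from compound 1 to compound 2 (0.68 log units; beyond the scatter), concerns cyclopentyl against 2-fluorobenzyl and says nothing about how one substituted phenyl compares with another on the saturated chain carbon. Since compound 2 and compound 3 share a benzyl-type group on that oxygen, the expected step in this assay is a 1.6-fold higher number from compound 2 to compound 3 (0.21 log units; within the scatter), likely within the scatter and of uncertain direction. Compound 3 is accordingly estimated at 0.5 nM, with a range of 0.15 nM to 2 nM.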

Compound 3, inhibition constant: 1.6 nM
Compound 3: middle estimate off by 3.2-fold (0.51 log units), on the low side; low and high end bracket the measured number.
By their numbers in this assay, from the lowest: compound 2; then compounds 1 and 3 (each within the scatter of the next).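

In this assay the group on the saturated chain carbon bound to an oxygen on an aromatic ring matters in its detail, not only as a benzyl-type group: a 5.2-fold higher number from compound 2 to compound 3 (0.71 log units; beyond the scatter) goes with 4-(trifluoromethyl)phenyl in place of 2-fluorophenyl. The gain over cyclopentyl seen with 2-fluorobenzyl does not extend to every benzyl-type group, as a 1.1-fold higher number from compound 1 to compound 3 (0.03 log units; within the scatter) goes with 4-(trifluoromethyl)benzyl in place of cyclopentyl and leaves the two within the scatter. Nothing on hand accounts for the difference between the two phenyl groups.

The exchange from compound 2 to compound 3 alters both the substituent and its place on the phenyl ring, so the compounds shown cannot tell which of the two goes with the higher number. As far as these compounds go, whether 4-fluorophenyl, 2-(trifluoromethyl)phenyl or unsubstituted phenyl on that carbon would sit nearer compound 2 or nearer compound 3 remains open.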